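The source may report more compounds than this note shows. Statements on the series, on what has been measured and on what is new or still open speak of the compounds shown alone.

The series shares the core of compound 1 `COc1cc(Nc2ncccc2-c2n[nH]c(Nc3ccccc3)n2)cc(OC)c1`. In a functional assay on A-431 cells (Homo sapiens) (a lower number here means that less compound is needed, a higher number that more compound is needed for the effect), compound 1 gives > 10000 nM, which is a limit of the assay and not a number. Compound 2 `COc1cc(Nc2ncccc2-c2n[nH]c(Nc3ccc(C#N)cc3)n2)cc(OC)c1` has no number to place it: compound 2 stands as "not determined" (no result reported). The only reference point is therefore (the limit of > 10000 nM in this assay, at which 1 of the 2 values shown sits). Compound 3 `COc1cc(Nc2ncccc2-c2n[nH]c(Nc3ccc4c(c3)OCCO4)n2)cc(OC)c1` carries 2,3-dihydro-1,4-benzodioxin-6-yl in place of 4-cyanophenyl on a nitrogen on an aromatic ring, (2,3-dihydro-1,4-benzodioxin-6-yl in place of 4-cyanophenyl on a nitrogen on an aromatic ring). Going by the values given here, no measured step exists in this assay, so no change beyond the scatter from that limit is expected, and no direction is favoured. The estimate for compound 3 is 10000 nM, with an expected range from 3000 nM to 30000 nM.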

Compound 3, half-maximal effective concentration: 117 nM
For compound 3 the middle estimate is 85-fold (1.93 log units) above the measured one; measured number outside the range, below it.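

In this assay, the group on the nitrogen on an aromatic ring proves able to move this read-out: 2,3-dihydro-1,4-benzodioxin-6-yl in place of phenyl gives an at least 85-fold lower number from compound 1 to compound 3 (1.93 log units; beyond the scatter). Compound 2 offers no comparison, so the change from 4-cyanophenyl cannot be read. The size of the step is only a floor, since the value of compound 1 is a limit: the limit of > 10000 nM in this assay, at which 1 of the 3 values shown sits.

Open, as far as these compounds go, is whether the closed dioxin ring is needed, or whether a single methoxy group or an amine on the phenyl ring would give a similar result.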